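A few compounds are considered here, and "the series" means these few. Any claim that something is new, unique, unknown or untested is made for them only; others in the source may bear on it.

Measured compounds:
compound 1 `Cc1nnc(C2(O)CCCCC2)[nH]1`, 392 ug/mL
compound 2 `Cc1nnc(C(O)C2CCC(O)C(O)C2)[nH]1`, 378 ug/mL
compound 3 `OC1(c2nnc(-c3ccccc3)[nH]2)CCCCC1`, 422 ug/mL

All three values come from an ADME assay on Vero cells (Chlorocebus sabaeus) for cytotoxicity, read by MTT assay, with a stated time of 72 h; on this read-out lower numbers stand for higher toxicity in this test and higher numbers for lower toxicity in this test. The three numbers sit within the usual scatter of one another, so the read-out does not separate compound 1, compound 2 and compound 3 in this assay.

Among the compounds with values here, the one counted change among the measured compounds is phenyl in place of methyl on an aromatic carbon. Its step in this assay is a 1.1-fold higher number from compound 1 to compound 3 (0.03 log units; within the scatter), so the phenyl leaves the cytotoxicity read-out essentially where the methyl had it.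

Compound 4 `OC1CCC(C(O)c2nnc(-c3ccccc3)[nH]2)CC1O` has not yet been measured in this assay. It relates to compound 2 as compound 3 relates to compound 1: phenyl in place of methyl on an aromatic carbon. The two "place" descriptions are not identical word for word. In the pair of compound 1 and compound 3 the ring atom bears a group of 7 heavy atoms; in the pair of compound 2 and compound 4 the ring atom bears a large group. The change is therefore the same kind of change, not the same change. The cores of compound 1 and compound 2 differ as well, and that difference is not broken down here. The same kind of change occurs in two pairs among the compounds shown.

Within the data shown here, for compound 4 in this assay the expected step is a 1.1-fold higher number from compound 2 to compound 4 (0.02 log units; within the scatter), because the only measured instance of this kind of change gave a 1.1-fold higher number from compound 1 to compound 3 (0.03 log units; within the scatter) from compound 1 to compound 3. The expectation for compound 4 is 400 ug/mL, with an estimated range from 250 ug/mL to 600 ug/mL.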

Compound 4, half-maximal cytotoxic concentration: 429 ug/mL
Estimate against measurement, compound 4: 1.1-fold (0.03 log units) below, within the range that was stated.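

In this assay, phenyl in place of methyl on an aromatic carbon of the core of compound 2 gives a 1.1-fold higher number from compound 2 to compound 4 (0.05 log units; within the scatter), and the read-out does not separate the two compounds. Set beside the earlier step, the change reads the same on both cores, so in this series the step measured on one core carried over to the other within the limits of this read-out: the same change on two cores in this assay, a 1.1-fold higher number (0.03 log units; within the scatter) from compound 1 to compound 3 and a 1.1-fold higher number (0.05 log units; within the scatter) from compound 2 to compound 4, 1.1-fold (0.02 log units) apart, within the scatter of two such steps

Within the data shown here, this agreement is a match between two steps that are both within the scatter, so it shows only that neither core separates phenyl from methyl in this cytotoxicity read-out. It does not show that a step of real size would carry over between these cores, it rests on two pairs only, and it says nothing of any other core or of any other read-out.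

Still open, from the compounds shown here alone, is whether a group other than methyl and phenyl on this aromatic carbon, such as an amine, a carboxylic acid or a longer chain, would give a step beyond the scatter. Also open, going by these compounds, is whether such a step would then read the same on the core of compound 1 and the core of compound 2.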